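A few compounds are considered here, and "the series" means these few. Any claim that something is new, unique, unknown or untested is made for them only; others in the source may bear on it.

Values so far in an ADME assay on NHDF cells (Homo sapiens) for cytotoxicity, read by MTT assay, with a stated time of 72 h; on this read-out lower numbers stand for stronger inhibition and higher numbers for weaker inhibition
compound 1 `COc1cccc(/C=C2\CCC/C(=C\c3ccc(Cl)cc3)C2=O)c1OC` gives 18600 nM
compound 2 `COc1cccc(/C=C2\CCC/C(=C\c3ccc(Cl)cc3Cl)C2=O)c1OC` gives 49200 nM
compound 3 `COc1cccc(/C=C2\CCC/C(=C\c3cc(Cl)cc(Cl)c3)C2=O)c1OC` gives 21600 nM

Of the three numbers, that of compound 3 is the second highest. The closest gap to it is a 1.2-fold higher number from compound 1 to compound 3 (0.06 log units; within the scatter) and the widest is a 2.3-fold lower number from compound 2 to compound 3 (0.36 log units; beyond the scatter) on this read-out.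

Compound 4 `COc1cccc(/C=C2\CCC/C(=C\c3ccc(O)c(Cl)c3)C2=O)c1OC` is not yet measured. The change is 3-chloro-4-hydroxyphenyl in place of 3,5-dichlorophenyl on a double-bonded chain carbon bound to a double-bonded ring carbon on a double-bonded chain carbon bound to a double-bonded ring carbon. Going by the values given here, no measured compound carries 3-chloro-4-hydroxyphenyl, so the evidence is indirect. The bearing steps are the three changes among the chlorinated aryl groups, the two above and a 2.6-fold higher number from compound 1 to compound 2 (0.42 log units; beyond the scatter) as the largest. None of them exceeds a modest size. In this assay no step beyond the scatter is therefore expected, and no direction is firmly expected. The estimated step is a 1.4-fold lower number from compound 3 to compound 4 (0.13 log units; within the scatter) for now. For compound 4 the estimated value is 16000 nM, with an expected range from 6000 nM to 42000 nM in this read-out.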

Compound 4, half-maximal inhibitory concentration: 39500 nM
For compound 4 the middle estimate is 2.5-fold (0.39 log units) below the measured one; measured number inside the range.
By their numbers in this assay, from the lowest: compounds 1, 3, 4 and 2 (each within the scatter of the next, the first and the last beyond it).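

In this assay, 3-chloro-4-hydroxyphenyl is the only group shown on a double-bonded chain carbon bound to a double-bonded ring carbon that carries a hydrogen-bond donor, yet the comparisons with the two dichlorophenyl groups stay within the scatter: a 1.8-fold higher number from compound 3 to compound 4 (0.26 log units; within the scatter), and a 1.2-fold lower number from compound 2 to compound 4 (0.10 log units; within the scatter). Only the comparison with 4-chlorophenyl clears the scatter, and modestly, with a 2.1-fold higher number from compound 1 to compound 4 (0.33 log units; beyond the scatter), so a hydrogen-bond donor at this place brings no step beyond the scatter against either dichlorophenyl group. No measurement at hand accounts for these steps.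

From the compounds shown here alone, whether the step from 4-chlorophenyl belongs to the hydroxyl or to the second substituent on the ring stays open, since 3-chloro-4-hydroxyphenyl differs from 4-chlorophenyl in both. An amine or a carboxylic acid in place of the hydroxyl would show whether the number in this assay depends on that particular group.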